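Aryl swap on the triazole nitrogen: expectation for compound 3

The source may report more compounds than this note shows. Statements on the series, on what has been measured and on what is new or still open speak of the compounds shown alone.

Going by the values given here, compound 2 `Cc1ccc(-n2cc(-c3ccccc3NS(=O)(=O)c3c[nH]c(=O)[nH]c3=O)nn2)cc1` holds the highest of the two numbers so far in a functional assay on SGC-7901 cells (Homo sapiens) for antiproliferative activity, read by MTT assay, with a stated time of 24 h (on this read-out higher numbers stand for weaker inhibition and lower numbers for stronger inhibition), where compound 2 gives 6390 nM; its nearest neighbour, compound 1 `Cc1cccc(-n2cc(-c3ccccc3NS(=O)(=O)c3c[nH]c(=O)[nH]c3=O)nn2)c1`, gives 3510 nM, and the step of a 1.8-fold higher number from compound 1 to compound 2 (0.26 log units; within the scatter) is within the scatter. Compound 3 `O=c1[nH]cc(S(=O)(=O)Nc2ccccc2-c2cn(-c3ccccc3F)nn2)c(=O)[nH]1` differs from compound 2 by 2-fluorophenyl in place of 4-methylphenyl on an aromatic nitrogen. Among the compounds with values here, the only measured step, from compound 1 to compound 2, shifted a methyl and stayed within the scatter, so it bears on this change only loosely. Compound 3 is therefore expected near 4500 nM, range 1500 nM to 14000 nM, with a step of a 1.4-fold lower number from compound 2 to compound 3 (0.15 log units; within the scatter) expected to be no larger than the scatter.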

Compound 3, half-maximal inhibitory concentration: 10800 nM
The estimate for compound 3 lay 2.4-fold (0.38 log units) below the measured number, and the stated range covers the measured number.
By their numbers in this assay, from the lowest: compounds 1, 2 and 3 (each within the scatter of the next, the first and the last beyond it).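

In this assay, going by these compounds alone, the change to 2-fluorophenyl on the aromatic nitrogen gives a 1.7-fold higher number from compound 2 to compound 3 (0.23 log units; within the scatter) and also a 3.1-fold higher number from compound 1 to compound 3 (0.49 log units; beyond the scatter) as the first step beyond the scatter. Within the data shown here, the number at this position therefore does move with the aryl group, though only one of the two comparisons separates. No measurement shown accounts for this shift.

The compounds shown leave open how an unsubstituted phenyl, a 4-methoxyphenyl or a benzyl group would read on this nitrogen. Going by these compounds, whether the fluorine or the loss of the methyl carries the step also stays open.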